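A few compounds are considered here, and "the series" means these few. Any claim that something is new, unique, unknown or untested is made for them only; others in the source may bear on it.

The account opens with compound 1 `COc1ccc(-c2cc(/C=C/C(=O)c3ccc(N)cc3)[nH]n2)cc1`, which in a functional assay on T47D cells (Homo sapiens) for cytotoxicity, read by sulforhodamine B assay, with a stated time of 48 h, tested at 0.01 uM (on this read-out higher numbers stand for a weaker effect at the one concentration tested and lower numbers for a stronger effect), gives 98%. Its companion, compound 2 `COc1ccc(C(=O)/C=C/c2cc(-c3cc(OC)c(OC)c(OC)c3)n[nH]2)cc1`, gives 96% in this assay. On these two numbers compound 1 and compound 2 cannot be told apart: the gap between them lies within the usual scatter, and at this concentration neither compound shows any marked effect.

Compound 3 `COc1ccc(-c2cc(/C=C/C(=O)c3ccc(N)cc3)[nH]n2)cc1OC` differs from compound 1 by methoxy in place of hydrogen on an aromatic carbon. Among the measured compounds shown here, no step between measured compounds in this set bears on such a change, so there is no measured precedent to draw on. Both compound 1 and compound 2 sit near the level of no effect at this concentration. On that basis the step of a number 1 percentage points lower from compound 1 to compound 3 (within the scatter) is expected to be no larger than the scatter, with no set direction. Compound 3 is therefore expected to give 97% in this assay, with a range from 88% to 104%.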

Compound 3, a percentage reported as activity, at one concentration (the size of the read-out at that concentration, not a potency): 85%
Compound 3: middle estimate off by 12 percentage points, on the high side; the measured number lies below the stated range.
By their numbers in this assay, from the lowest: compound 3; then compounds 2 and 1 (each within the scatter of the next).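

Methoxy in place of hydrogen on an aromatic carbon, ortho to a methoxy group and meta to a large group, gives in this assay a number 13 percentage points lower from compound 1 to compound 3 (beyond the scatter), the first difference in this set that lies beyond the scatter. This position therefore responds to substitution even at this low concentration, with the added methoxy moving the read-out towards a stronger effect, although this rests on a single modest step. No measurement available here accounts for that step.

The compounds shown leave open whether this step is specific to methoxy or would also appear with a hydroxy group, an ethoxy group or a chlorine atom at the same place. They also leave open whether hydrogen and methoxy at this place would differ by a similar amount on a different core.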